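Capping the aminoethyl sulfonamide nitrogen: stability outlook

The source may hold more compounds than are shown below. What is called first, only, known or untested is meant among the compounds shown, and "the series" means these compounds.

Measured compounds:
compound 1, `CC(C)S(=O)(=O)NC(=O)c1ccc(Nc2nc(NC3(c4ccc(Cl)cc4)CC3)nc(OCC(F)(F)F)n2)cc1` — 96%
compound 2, `O=C(NS(=O)(=O)c1ccc(F)cc1)c1ccc(Nc2nc(NC3(c4ccc(Cl)cc4)CC3)nc(OCC(F)(F)F)n2)cc1` — 99%
compound 3, `NCCS(=O)(=O)NC(=O)c1ccc(Nc2nc(NC3(c4ccc(Cl)cc4)CC3)nc(OCC(F)(F)F)n2)cc1` — 100%

In an ADME assay on microsomes from liver (Rattus norvegicus) for metabolic stability, with a stated time of 10 min (a higher number here means that more of the compound is left, a lower number that less of the compound is left), compound 3 holds the highest of the three numbers, yet its gap to compound 2 and to compound 1 is within the scatter, so the three compounds cannot be ranked. The three measured steps all exchange the group on the sulfonyl sulfur: a number 3 percentage points higher from compound 1 to compound 2 (within the scatter), a number 4 percentage points higher from compound 1 to compound 3 (within the scatter) and a number 1 percentage points higher from compound 2 to compound 3 (within the scatter), each within the scatter. Every measured value sits close to the top of the scale.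

Compound 4, `CC(C)NC(=O)NCCS(=O)(=O)NC(=O)c1ccc(Nc2nc(NC3(c4ccc(Cl)cc4)CC3)nc(OCC(F)(F)F)n2)cc1`, differs from compound 3 by isopropylcarbamoyl in place of hydrogen on an amine nitrogen. Going by the values given here, no measured step touches this amine nitrogen; the only comparisons available concern the sulfonyl substituent and were all within the scatter. With compound 3 already at 100%, there is little room upward, and nothing among the shown steps points to a loss. Compound 4 is therefore expected to show a number 5 percentage points lower from compound 3 to compound 4 (within the scatter), no step beyond the scatter. The estimate for compound 4 is 95%, with a range from 85% to 100%.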

Compound 4, percent of the compound remaining in the liver assay: 97%
Compound 4: the middle estimate sits 2 percentage points below what was measured; the measured number falls inside the stated range.
By their numbers in the liver assay, from the lowest: compounds 1, 4, 2 and 3 (each within the scatter of the next).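

Going by these compounds alone, in the liver assay, compound 4 gives the first reading for a change on the amine nitrogen rather than on the sulfonyl sulfur, and that position accepts isopropylcarbamoyl with all three steps within the scatter: a number 3 percentage points lower from compound 3 to compound 4 (within the scatter), a number 2 percentage points lower from compound 2 to compound 4 (within the scatter) and a number 1 percentage points higher from compound 1 to compound 4 (within the scatter). The same change does register in a physicochemical assay for permeability, using PAMPA, at pH 7.4 (a higher number here means that the compound crosses the layer faster, a lower number that the compound crosses the layer more slowly), where compound 3 gives 153 nm/s and compound 4 gives 45 nm/s, a 3.4-fold lower number from compound 3 to compound 4 (0.53 log units; beyond the scatter). So the step that leaves the stability reading within the scatter goes beyond the scatter in the permeability reading.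

From the compounds shown here alone, whether an acetyl or a methyl group on the amine nitrogen would give a smaller step in the physicochemical assay remains open. So does whether a carboxylic acid in place of the amine would hold the number in the liver assay.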